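A few compounds are considered here, and "the series" means these few. Any claim that something is new, unique, unknown or untested is made for them only; others in the source may bear on it.

Among the measured compounds shown here, in a functional assay on KB cells (Homo sapiens) for antiproliferative activity, with a stated time of 72 h (on this read-out lower numbers stand for stronger inhibition and higher numbers for weaker inhibition), compound 1 `COc1ccc(-n2ccc3c(OC)c(OC)c(OC)cc32)cc1` gives 186 nM, the lower of the two numbers measured so far, while compound 2 `COc1ccc(-n2ccc3c(OC)c(OC)c(OC)cc32)cc1N` gives 3250 nM. Compound 3 `COc1cc2c(ccn2-c2ccc(N(C)C)cc2)c(OC)c1OC` carries dimethylamino in place of methoxy on an aromatic carbon, para to a large group: dimethylamino in place of methoxy on an aromatic carbon. For the measured compounds named here, the only measured step, a 17-fold higher number from compound 1 to compound 2 (1.24 log units; beyond the scatter), is large, but it puts amino in place of hydrogen, a different change, so it bears only loosely. No clear shift beyond the scatter is therefore expected, and the estimated step is a 1.6-fold higher number from compound 1 to compound 3 (0.21 log units; within the scatter). Compound 3 is expected at 300 nM, with an estimated range of 60 nM to 1500 nM.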

Compound 3, half-maximal inhibitory concentration: 148 nM
Beside the measured number, compound 3's estimate is 2.0-fold (0.31 log units) above it; the range from low to high includes it.
By their numbers in this assay, from the lowest: compounds 3 and 1 (each within the scatter of the next); then compound 2.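

In this assay, dimethylamino in place of methoxy on an aromatic carbon, para to a large group, gives a 1.3-fold lower number from compound 1 to compound 3 (0.10 log units; within the scatter). The methoxy at this place is therefore not required to keep the number in this range, since dimethylamino serves equally well in this assay. No measurement at hand gives a reason for this result. The compounds shown leave open whether a carboxylic acid or a longer chain such as butoxy at this place would also keep the number within the scatter of compound 1.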